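This account rests on a few compounds, and the source may have more. Where it says the series, first, only, none or still open, it means among the compounds named here.

The compounds measured so far in an ADME assay on Vero cells (Chlorocebus sabaeus) for cytotoxicity, read by MTT assay, with a stated time of 72 h; a lower number here means that less compound is tolerated, a higher number that more compound is tolerated:

Compound 1, `COc1ccc(C2=NN(c3ccc(S(N)(=O)=O)cc3)C(c3cn(-c4ccccc4)nc3-c3ccc(F)cc3)C2)cc1`: > 53100 nM — a limit of this assay, not a number.
Compound 2, `COc1ccc(C2=NN(c3ccc(S(N)(=O)=O)cc3)C(c3cn(-c4ccccc4)nc3-c3ccc(Cl)cc3)C2)cc1`: 31300 nM.
Compound 3, `COc1ccc(C2=NN(c3ccc(S(N)(=O)=O)cc3)C(c3cn(-c4ccccc4)nc3-c3ccc(C)cc3)C2)cc1`: > 36600 nM — again a limit of this assay, not a number.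

Compound 3 thus stands at one of the two limits among the three values; only a limit is known for it, and the same holds for compound 1. The three compounds share one core and differ only in the group on the phenyl attached to the pyrazole. Compound 4, `COc1ccc(C2=NN(c3ccc(S(N)(=O)=O)cc3)C(c3cn(-c4ccccc4)nc3-c3ccc(OC)cc3)C2)cc1`, continues that series: methoxy in place of methyl on an aromatic carbon.

The measured steps all concern this same position. From compound 1 to compound 2 this assay moved by an at least 1.6-fold lower number from compound 1 to compound 2 (0.22 log units; that floor lies within the scatter), a floor within the scatter and tied to the limit of > 53100 nM in this assay, at which 1 of the 3 values shown sits. The step that the two limits leave unreadable from compound 1 to compound 3 is bounded on both sides by the limit of > 36600 nM in this assay, at which 1 of the 3 values shown sits, and (the limit of > 53100 nM in this assay, at which 1 of the 3 values shown sits). The closest comparison, an at least 1.1-fold higher number from compound 2 to compound 3 (0.06 log units; that floor lies within the scatter), is again a floor within the scatter. None of these steps shows a change beyond the scatter, so for compound 4 no step beyond the scatter is expected in this assay, in either direction. The estimated step from compound 3 to compound 4 is therefore a step that the limit leaves unreadable from compound 3 to compound 4. Compound 4 is expected to give about 45000 nM, within a range from 20000 nM to 100000 nM, and quite possibly only a limit.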

Compound 4, half-maximal cytotoxic concentration: 104000 nM
Beside the measured number, compound 4's estimate is 2.3-fold (0.36 log units) below it; measured number above the stated range.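

In this assay, within the data shown here, exchanging chloro for methoxy on this aromatic carbon, para to a large group, gives the first readable step at this position that lies beyond the scatter: a 3.3-fold higher number from compound 2 to compound 4 (0.52 log units; beyond the scatter). Among these compounds, the group on this phenyl can therefore shift the tolerated concentration by a modest amount, at least for this one pair, which the earlier comparisons, all floors within the scatter or unreadable, could not show. Compound 1 and compound 3 are known only as limits of the assay, so the steps from each of them to compound 4 cannot be read, and the change from 4-methylphenyl to 4-methoxyphenyl remains without a size.

The compounds shown therefore leave open where the true values of compound 1 and compound 3 lie relative to compound 4, so no order among fluoro, methyl and methoxy can be given. They also leave open how this assay responds when this same aromatic carbon carries an amine, a carboxylic acid or a longer chain such as ethoxy.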